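Phenyl to 4-chlorophenyl in a small cytotoxicity series

This account rests on a few compounds, and the source may have more. Where it says the series, first, only, none or still open, it means among the compounds named here.

Of the compounds shown here, three of the shared core have been measured in a functional assay on A549 cells (Homo sapiens) for cytotoxicity; on this read-out higher numbers stand for weaker inhibition and lower numbers for stronger inhibition. Compound 1 `O=C1NC(c2ccc(Br)cc2)CN1S(=O)(=O)c1ccc(Cl)cc1` gives 161000 nM in this assay. Compound 2 `O=C1NC(c2ccc(Br)cc2)CN1S(=O)(=O)c1ccc2c(c1)CCC2` gives 33900 nM. Compound 3 `Cc1ccc(C2CNC(=O)N2S(=O)(=O)c2ccccc2)cc1` gives 157000 nM, the second highest of the three numbers; it sits within the scatter of compound 1 and well above compound 2, which is the only one of the three clearly apart from the others.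

Compound 4 `Cc1ccc(C2CNC(=O)N2S(=O)(=O)c2ccc(Cl)cc2)cc1` is not yet measured. It differs from compound 3 in one place: chloro in place of hydrogen on an aromatic carbon. Among the measured compounds shown here, no measured pair shows exactly this change. Compound 1 already carries a chloro group at the same place, and its number in this assay lies within the scatter of compound 3, so nothing here points to a step beyond the scatter in either direction. The step from compound 3 to compound 4 is therefore expected to be small, a 1.0-fold lower number from compound 3 to compound 4 (0.02 log units; within the scatter). For compound 4 the estimate in this assay is 150000 nM, with a range from 60000 nM to 350000 nM.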

Compound 4, half-maximal inhibitory concentration: 266000 nM
Compound 4: middle estimate off by 1.8-fold (0.25 log units), on the low side; the range from low to high includes it.
By their numbers in this assay, from the lowest: compound 2; then compounds 3, 1 and 4 (each within the scatter of the next).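

Phenyl to 4-chlorophenyl, on an aromatic carbon of the six-membered ring and para to a large group, now has its first direct reading in the series: in this assay the change gives a 1.7-fold higher number from compound 3 to compound 4 (0.23 log units; within the scatter). Earlier, the chloro group could only be seen in compound 1, which carries a bromo group in place of the methyl group, so its effect could not be read alone. With the rest of compound 3 held constant, adding this one chlorine atom leaves the number within the scatter, and no supporting data bear on this result.

From the compounds shown here alone, whether an amine, a carboxylic acid or a methoxy group at the same place would give a step beyond the scatter remains open. Also open, going by these compounds, is whether phenyl to 4-chlorophenyl gives a similar step on the bromo-bearing background of compound 1.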